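The compounds below may be only part of what the source reports. "The series", "measured", "known", "first", "only" and "open" are said of these compounds alone.

In a physicochemical assay for lipophilicity, using the shake flask method, in phosphate buffer, measured as octanol-water partition, at pH 7.4 (a higher number here means a more lipophilic compound, a lower number a more polar compound), compound 1 `C[C@@H]1CN(c2ncc(OCc3ccc(S(C)(=O)=O)cc3)cn2)[C@@H](C)CN1C(=O)OC(C)(C)C` gives only a limit, > 3.7, and not a number. Going by the values given here, compound 2 `C[C@@H]1CN(c2ncc(F)cn2)CCN1c1ncc(OCc2ccncc2C#N)cn1` measures 3.4 and so holds the only true number so far, which makes it the one firm point to start from. Compound 3 `C[C@@H]1CN(c2nc(C3CC3)no2)CCN1c1ncc(OCc2ccncc2C#N)cn1` differs from compound 2 in a single place, with 3-cyclopropyl-1,2,4-oxadiazol-5-yl in place of 5-fluoropyrimidin-2-yl on an amine nitrogen in a ring. The rest of the molecule stays the same. Among the compounds with values here, no measured pair of compounds shows what this swap does, so any forecast in this assay remains loose. The estimated step is a number 0.30 log units lower from compound 2 to compound 3 (within the scatter), a small expected drop that hardly clears the usual scatter of repeated measurements. For compound 3 the expected value is 3.1, with an estimated range from 2.6 to 3.6.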

Compound 3, distribution coefficient: 3.5
Beside the measured number, compound 3's estimate is 0.40 log units below it; the measured number falls inside the stated range.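

In this assay, this position now has its first readable step: putting 3-cyclopropyl-1,2,4-oxadiazol-5-yl in place of 5-fluoropyrimidin-2-yl on the amine nitrogen in the ring gives a number 0.10 log units higher from compound 2 to compound 3 (within the scatter). A six-membered aromatic ring with 2 hetero atoms can therefore give way here to a five-membered aromatic ring with 3 hetero atoms plus a three-membered carbon ring, with no change in the read-out beyond the scatter. Going by these compounds alone, one value shown, that of compound 1, is only a limit and adds no second step: the limit of > 3.7 in this assay, at which 1 of the 3 values shown sits.

Going by these compounds, whether a group carrying a carboxylic acid or an amine at this place would shift the number beyond the scatter stays open. So does whether this same swap would give a similar step on a different core.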